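Sec-butyl to propyl on the shared core

The compounds below may be only part of what the source reports. "The series", "measured", "known", "first", "only" and "open" are said of these compounds alone.

Compound 1 `CCC(C)n1cnc2c(NCc3ccc(C(=O)Nc4ccccc4N)cc3)nc(Cl)nc21` stands highest of the two numbers in a functional assay on HCT-116 cells (Homo sapiens) for antiproliferative activity, read by CCK-8 assay, with a stated time of 72 h, tested at 8 uM (on this read-out higher numbers stand for a stronger effect at the one concentration tested and lower numbers for a weaker effect), where compound 1 gives 75.1%. Compound 2 `Nc1ccccc1NC(=O)/C=C/c1ccc(Cn2cnc3c(Nc4cccc(OC(F)(F)F)c4)nc(Cl)nc32)cc1` gives 5.23% in this assay, a gap beyond the scatter. Compound 3 `CCCn1cnc2c(NCc3ccc(C(=O)Nc4ccccc4N)cc3)nc(Cl)nc21` has not yet been measured. The change from compound 1 to compound 3 is hydrogen in place of methyl on a saturated chain carbon bound to an aromatic nitrogen and a saturated chain carbon. For the measured compounds named here, no step between measured compounds carries this change, so the expectation rests on compound 1 alone. For a change of this size, a number 7.1 percentage points lower from compound 1 to compound 3 (within the scatter) is expected to stay within the scatter, if anything slightly downward. Compound 3 is estimated at 68% in this assay, with a range from 45% to 85%.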

Compound 3, a percentage reported as inhibition, at one concentration (the size of the read-out at that concentration, not a potency): 29.6%
Beside the measured number, compound 3's estimate is 38.4 percentage points above it; measured number outside the range, below it.
By their numbers in this assay, from the lowest: compound 2; then compound 3; then compound 1.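

In this assay, this position proves sensitive to a small change: sec-butyl to propyl, with one methyl leaving a saturated chain carbon bound to an aromatic nitrogen and a saturated chain carbon, gives a number 45.5 percentage points lower from compound 1 to compound 3 (beyond the scatter). For the compounds shown here, compound 2 differs from compound 1 in more than one place, so only this step isolates the chain. Nothing measured here accounts for the drop. Still open, going by these compounds, is whether an isopropyl group, a cyclopentyl ring or a longer chain such as n-butyl in place of sec-butyl would read like compound 1 or like compound 3.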